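Swapping methoxycarbonyl for hydroxy on compound 3

The compounds below may be only part of what the source reports. "The series", "measured", "known", "first", "only" and "open" are said of these compounds alone.

- compound 1 `COc1cc(C2=C(c3cc(C)c(OC)c(C)c3)C(O)CC2=O)cc(OC)c1OC`: > 100 ug/mL, a limit of the assay
- compound 2 `COc1cc(C2=C(c3cc(C)c(OC)c(C)c3)C(OC(C)=O)CC2=O)cc(OC)c1OC`: > 100 ug/mL, a limit of the assay
- compound 3 `COC(=O)c1cc(C2=C(c3cc(OC)c(OC)c(OC)c3)C(=O)CC2O[SiH2]C(C)(C)C)ccc1OC`: > 100 ug/mL, a limit of the assay

All three entries come from an ADME assay on L132 cells (Homo sapiens) for cytotoxicity, read by MTT assay, with a stated time of 72 h; on this read-out higher numbers stand for weaker inhibition and lower numbers for stronger inhibition. In this assay compound 3 gives > 100 ug/mL, which is a limit and not a number. It shares this position with the other two compounds, so the data so far consist of the limit of > 100 ug/mL in this assay, at which 3 of the 3 values shown sit.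

The next compound is compound 4 `COc1ccc(C2=C(c3cc(OC)c(OC)c(OC)c3)C(=O)CC2O[SiH2]C(C)(C)C)cc1O`, which differs from compound 3 in one place: hydroxy in place of methoxycarbonyl on an aromatic carbon. Hydroxy stands in place of methoxycarbonyl on an aromatic carbon, ortho to a methoxy group, turning 4-methoxy-3-(methoxycarbonyl)phenyl into 3-hydroxy-4-methoxyphenyl.

Within the data shown here, only one measured step exists to compare with, a step that the two limits leave unreadable from compound 1 to compound 2. That step is a different change, acetyl in place of hydrogen on an oxygen on a saturated carbon, and it has no readable size. No size or direction can therefore be carried over, and no step beyond the scatter is expected in this assay.

The expected step, estimated with low confidence, is a number no higher from compound 3 to compound 4 (the limit leaves the size open). The estimate for compound 4 is 100 ug/mL, with an expected range from 25 ug/mL to 200 ug/mL.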

Compound 4, half-maximal inhibitory concentration: < 1 ug/mL
Compound 4: only a limit was reported; the forecaster's own chance of this, stated with the estimate: 65%; at least 100-fold (2.00 log units) between middle value and limit.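

In this assay, replacing methoxycarbonyl with hydroxy at this ring position gives an at least 100-fold lower number from compound 3 to compound 4 (2.00 log units; beyond the scatter), so a single group at this place can turn a compound with no readable effect on these cells into a strongly inhibiting one. The earlier compounds shown here could not show this: compound 1, compound 2 and compound 3 all sat at the same upper limit, and no difference among them could be read. Compound 4 also gives a limit and not a number, so the true size of the step stays unknown, and it stands alone at the low end of the values shown: the limit of < 1 ug/mL in this assay, at which 1 of the 4 values shown sits.

The compounds shown cannot separate the loss of methoxycarbonyl from the arrival of hydroxy, since both happen in the same step, and plain hydrogen, an amine or a carboxylic acid at this place could help tell the two apart. They also leave open whether the same swap has a similar effect when the rest of the molecule differs, for example with the ring substituents and free hydroxy group of compound 1.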